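A few compounds are considered here, and "the series" means these few. Any claim that something is new, unique, unknown or untested is made for them only; others in the source may bear on it.

Of the compounds shown here, three have been measured in a functional assay on MCF7 cells (Homo sapiens) for cytotoxicity, read by sulforhodamine B assay, with a stated time of 48 h; a higher number here means a weaker inhibitor, a lower number a stronger inhibitor. Compound 1, `CCNC(=O)Nc1cccc(S(=O)(=O)Oc2ccccc2C)c1`, gives 55000 nM. Compound 2, `CCNC(=O)Nc1cccc(S(=O)(=O)Oc2ccccc2CC)c1`, gives 31000 nM. Compound 3, `CCNC(=O)Nc1cccc(S(=O)(=O)Nc2ccccc2C)c1`, gives 108000 nM. How the core of compound 3 differs from the core of compound 1 is not broken down here; their two values stand in the same range, with compound 3 at the highest number of the three.

The change from compound 1 to compound 2 is methyl in place of hydrogen on a saturated chain carbon bound to an aromatic carbon, and it made a step of a 1.8-fold lower number from compound 1 to compound 2 (0.25 log units; within the scatter).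

Compound 4, `CCNC(=O)Nc1cccc(S(=O)(=O)Nc2ccccc2CC)c1`, is not yet measured. Among the compounds with values here, it differs from compound 3 by methyl in place of hydrogen on a saturated chain carbon bound to an aromatic carbon, which is the same change as the one from compound 1 to compound 2, made at the same kind of place and on a different core. Because the earlier step was a 1.8-fold lower number from compound 1 to compound 2 (0.25 log units; within the scatter), a step of about the same modest size is expected here, so that compound 4 is expected to show a step of a 1.7-fold lower number from compound 3 to compound 4 (0.22 log units; within the scatter). Within the data shown here, this rests on only one measured pair, so the expectation is loose, and a result anywhere near the value of compound 3 would not be surprising. Compound 4 is therefore estimated at 65000 nM, with a likely range from 30000 nM to 150000 nM.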

Compound 4, half-maximal inhibitory concentration: 48000 nM
The estimate for compound 4 lay 1.4-fold (0.13 log units) above the measured number, within the range that was stated.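

Replacing the 2-methylphenyl group of compound 3 with a 2-ethylphenyl group, which adds one methyl on the saturated chain carbon bound to an aromatic carbon, gave a modest change in this assay: a 2.3-fold lower number from compound 3 to compound 4 (0.35 log units; beyond the scatter) 

Set beside the earlier step, the same change moved the number in the same direction on both cores, and the two steps are close enough in size to count as alike: the same change on two cores in this assay, a 1.8-fold lower number (0.25 log units; within the scatter) from compound 1 to compound 2 and a 2.3-fold lower number (0.35 log units; beyond the scatter) from compound 3 to compound 4, 1.3-fold (0.10 log units) apart, within the scatter of two such steps 

The step carried over between these two cores at about the same small size. Within the data shown here, this rests on only two pairs, one of whose steps lies within the scatter, so it is no rule for other cores. It says nothing about why the number moves.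

Still open, on these data alone, is whether a propyl group or a longer chain at this place would lower the number further, and whether an amine or a carboxylic acid on that chain would reverse the trend. Also open, as far as these compounds go, is whether the step would hold on a third core, or in any test other than this assay.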